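A few compounds are considered here, and "the series" means these few. Any claim that something is new, unique, unknown or untested is made for them only; others in the source may bear on it.

Working notes on the series. Compound 1 `OCCCCCC(O)c1ccc(-c2ccccc2)cc1` carries an unsubstituted distal phenyl on the shared core. Among the measured compounds shown here, in a functional assay on J774 cells (Mus musculus) for cytotoxicity, read by resazurin assay (a lower number here means a stronger inhibitor, a higher number a weaker inhibitor), compound 1 gives 22000 nM, the higher of the two numbers measured so far; compound 2 `OCCCCCC(O)c1ccc(-c2ccc(F)cc2F)cc1`, with two fluorine atoms on that ring, gives 8000 nM in this assay, a gap beyond the usual scatter. Compound 3 `OCCCCCC(O)c1ccc(-c2ccc(C(F)(F)F)cc2)cc1` is not yet measured. It differs from compound 1 by trifluoromethyl in place of hydrogen on an aromatic carbon, the new group sitting para to a large group on that ring. For the measured compounds named here, with no measured step of this exact kind, the expectation rests on compound 2 at 8000 nM, where substitution on the same ring went with a lower number than compound 1 at 22000 nM. For compound 3 a step of a 2.4-fold lower number from compound 1 to compound 3 (0.39 log units; beyond the scatter) toward a lower number is expected, of modest size. Compound 3 is estimated at 9000 nM in this assay, within 3000 nM to 25000 nM.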

Compound 3, half-maximal inhibitory concentration: 13000 nM
Compound 3: middle estimate off by 1.4-fold (0.16 log units), on the low side; low and high end bracket the measured number.
By their numbers in this assay, from the lowest: compounds 2, 3 and 1 (each within the scatter of the next, the first and the last beyond it).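

In this assay, among the compounds shown here, trifluoromethyl in place of hydrogen on an aromatic carbon, para to a large group, gives a 1.7-fold lower number from compound 1 to compound 3 (0.23 log units; within the scatter), the first single-place change. The step lies within the usual scatter, so at this position the exchange of hydrogen for a group of 4 heavy atoms cannot be told apart from no change in this assay. For the compounds shown here, what compound 2 could not show on its own, with no single-place step linking it to compound 1, is now visible: this one substitution on the distal phenyl, taken alone, does not separate compound 3 from compound 1. Nothing measured here bears on the reason for the size of this step.

Still open, on these data alone, is whether a nitrile, an amine or a carboxylic acid at the same place would give a step beyond the scatter. Also open, as far as these compounds go, is whether a single fluorine there would do so.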